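The source may hold more compounds than are shown below. What is called first, only, known or untested is meant among the compounds shown, and "the series" means these compounds.

Working notes on the series. Compound 1 `CN(C)c1ccc2nc(-c3cccc4ccccc34)[nH]c(=O)c2c1` is the reference point. Within the data shown here, in an assay on isolated protein for inhibition of DNA topoisomerase 1 (Homo sapiens), with a stated time of 30 min, tested at 100 uM (on this read-out higher numbers stand for a stronger effect at the one concentration tested and lower numbers for a weaker effect), compound 1 gives 100%, the higher of the two numbers so far, yet the gap to its only neighbour lies within the scatter, so the two cannot be told apart on this read-out. Among the measured compounds shown here, that neighbour, compound 2 `Cc1ccc2nc(-c3cccc(OC(F)(F)F)c3)[nH]c(=O)c2c1`, gives 98.6% in this assay and carries a different group on the same core as well as a different aryl on the other side, so no single-point step between measured compounds is available. The next compound, compound 3 `CCN(CC)c1ccc2nc(-c3cccc4ccccc34)[nH]c(=O)c2c1`, differs from compound 1 in one place: diethylamino in place of dimethylamino on an aromatic carbon. With both measured numbers already at or near the ceiling of the read-out, little room remains upward, and no downward trend is known. The expected step is a number 5 percentage points lower from compound 1 to compound 3 (within the scatter), none beyond the scatter. Compound 3 is therefore expected to give about 95% in this assay, with a range from 80% to 100%.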

Compound 3, a percentage reported as inhibition, at one concentration (the size of the read-out at that concentration, not a potency): 90.4%
Compound 3: middle estimate off by 4.6 percentage points, on the high side, within the range that was stated.
By their numbers in this assay, from the lowest: compounds 3, 2 and 1 (each within the scatter of the next).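

In this assay, the series now has its first single-place comparison: diethylamino in place of dimethylamino on this aromatic carbon gives a number 9.6 percentage points lower from compound 1 to compound 3 (within the scatter) on the shared core. At this one concentration, the position therefore takes the change from 3 to 5 heavy atoms, with no ring added and no net charge, without a shift that can be told apart from the scatter; the read-out gives no potency, so any difference that a full concentration series might show stays hidden. No available measurement bears on what lies behind this step.

Going by these compounds, it remains open whether a longer chain such as dipropylamino, a cyclic amine such as pyrrolidine or morpholine, or a carboxylic acid at this carbon would move the number beyond the scatter. On these data alone, the primary amine and the unsubstituted carbon are equally open as lower-size comparisons at this position.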